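Trading Cyclohexyl for Benzyl on the Ring Nitrogen

The source may hold more compounds than are shown below. What is called first, only, known or untested is meant among the compounds shown, and "the series" means these compounds.

compound 1 `Brc1cn2ccnc2c(-c2ccc3ncn(C4CCCCC4)c3c2)n1`: 13.4%
compound 2 `O=Cc1ccc(-c2cn3ccnc3c(-c3ccc4ncn(C5CCCCC5)c4c3)n2)cc1`: 56.5%
compound 3 `Fc1ccccc1-c1cn2ccnc2c(-c2ccc3ncn(C4CCCCC4)c3c2)n1`: 6.5%

Of the compounds shown here, three sharing one core have been measured in a functional assay on SK-MEL-5 cells (Homo sapiens) for inhibition, read by sulforhodamine B assay, with a stated time of 48 h, tested at 10 uM; a lower number here means less inhibition, a higher number more inhibition at the concentration tested (going by the name of the read-out). Compound 2 gives 56.5%, the highest of the three numbers, and both neighbours lie beyond the scatter below it: the step of a number 43.1 percentage points higher from compound 1 to compound 2 (beyond the scatter) is large, as is the step of a number 50 percentage points lower from compound 2 to compound 3 (beyond the scatter). Compound 1 and compound 3, by contrast, are separated only by a number 6.9 percentage points lower from compound 1 to compound 3 (within the scatter), which stays within the scatter.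

Compound 4 `O=Cc1ccc(-c2cn3ccnc3c(-c3ccc4ncn(Cc5ccccc5)c4c3)n2)cc1` keeps the 4-formylphenyl of compound 2 and changes a different place: benzyl in place of cyclohexyl on an aromatic nitrogen. Every measured step alters the group on the aromatic carbon, so none of them bears on a change at the ring nitrogen. Going by the values given here, no measured step shows how much this assay responds to a swap of cyclohexyl for benzyl; the expectation therefore rests on the nearest measured compound alone, and the step of a number 6.5 percentage points lower from compound 2 to compound 4 (within the scatter) is expected to stay within the scatter.

Among the compounds with values here, on that basis compound 4 is estimated to give 50% in this assay, with a range from 25% to 72% that is wide because no measured pair tests this position.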

Compound 4, a percentage reported as inhibition, at one concentration (the size of the read-out at that concentration, not a potency): 56.5%
Estimate against measurement, compound 4: 6.5 percentage points below; the range from low to high includes it.
By their numbers in this assay, from the lowest: compounds 3 and 1 (each within the scatter of the next); then compounds 2 and 4 (each within the scatter of the next).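

Going by these compounds alone, the swap of cyclohexyl for benzyl on the aromatic nitrogen gives the first reading at this position: in this assay, the result is no change at the digits printed from compound 2 to compound 4 (within the scatter). Within the data shown here, with the 4-formylphenyl group held in place, the non-aromatic carbon ring on this nitrogen can therefore give way to the aromatic carbon ring of benzyl without the inhibition leaving the scatter, whereas two of the three earlier steps, all on the aromatic carbon, were large and only the step between compound 1 and compound 3 was not. No available evidence explains why the two groups read alike.

On these data alone, it remains open whether this match carries over to compounds with bromo or 2-fluorophenyl on the aromatic carbon, since the benzyl swap is read here only with 4-formylphenyl, and a single concentration cannot show whether compound 2 and compound 4 also match in potency. As far as these compounds go, it is equally open how this assay would respond to a longer alkyl chain, a chain ending in an amine or a carboxylic acid on the same nitrogen, or to a substituted benzyl group.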